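A few compounds are considered here, and "the series" means these few. Any claim that something is new, unique, unknown or untested is made for them only; others in the source may bear on it.

In a functional assay on the whole organism with Mus musculus as the target, in the writhing test, at a dose of 100 mg/kg by the intraperitoneal route (on this read-out higher numbers stand for more inhibition at the one dose given (going by the name of the read-out) and lower numbers for less inhibition), compound 2 `c1ccc(COc2nc3ccccc3s2)cc1` gives 51.9%. Compound 1 `Brc1ccccc1COc1nc2ccccc2s1` gives 51.9% in this assay, so compound 2 stands level with compound 1 at the digits shown. Compound 3 `Cc1ccc(COc2nc3ccccc3s2)cc1` is recorded in this assay as "not active" (no number reported), with no number behind it, so it offers nothing that can be weighed as a step. Within the data shown here, the one step between measured compounds that differ in a single place is no change at the digits printed from compound 1 to compound 2 (within the scatter); it concerns a halogen on the same aromatic carbon of the shared core. Compound 4 `Fc1ccccc1COc1nc2ccccc2s1` differs from compound 2 by fluoro in place of hydrogen on an aromatic carbon. Because the step of no change at the digits printed from compound 1 to compound 2 (within the scatter) showed nothing beyond the scatter when a bromo on that aromatic carbon was exchanged for hydrogen, the step expected for compound 4 in this assay is likewise small, and the estimated step is a number 1.9 percentage points lower from compound 2 to compound 4 (within the scatter). Compound 4 is therefore expected to give about 50% in this assay, with a range from 30% to 65%.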

Compound 4, a percentage reported as inhibition, in the whole organism at one dose (the size of the read-out at that dose, not a potency): 51.9%
Estimate against measurement, compound 4: 1.9 percentage points below; measured number inside the range.
By their numbers in this assay, from the lowest: compounds 1, 2 and 4 (each within the scatter of the next).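

In this assay fluoro in place of hydrogen gives no change at the digits printed from compound 2 to compound 4 (within the scatter) and fluoro in place of bromo gives no change at the digits printed from compound 1 to compound 4 (within the scatter) at this place on the six-membered aromatic ring of carbon only, ortho to a large group. The earlier compounds shown here had left only bromo and hydrogen level here, whereas this read-out at its single dose now separates neither of these two halogens from hydrogen nor the halogens from each other. Nothing given here accounts for this levelness.

Going by these compounds, whether an amine, a carboxylic acid or a longer chain at this place would also stay level with hydrogen remains open. Compound 3 carries no number in this read-out, so its relation to the other compounds cannot be read as a step.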